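The source may hold more compounds than are shown below. What is called first, only, known or untested is meant among the compounds shown, and "the series" means these compounds.

Measured so far:
compound 1, `COc1cccc(OC)c1C(=O)Nc1c[nH]nc1C(=O)Nc1ccncc1`, with > 50000 nM
compound 2, `CO[C@H]1CC[C@H](NC(=O)c2n[nH]cc2NC(=O)c2ncoc2-c2ccccc2)CC1`, with 28000 nM
compound 3, `CO[C@H]1CC[C@H](NC(=O)c2n[nH]cc2NC(=O)c2ccc(F)cc2F)CC1`, with 11000 nM

In an ADME assay on MRC5 cells (Homo sapiens) for inhibition, with a stated time of 72 h (on this read-out higher numbers stand for an effect only at larger amounts of compound and lower numbers for an effect already at smaller amounts), compound 1 gives > 50000 nM, which is a limit of the assay and not a number. Compound 1 thus stands at the limit of > 50000 nM in this assay, at which 1 of the 3 values shown sits. In this assay compound 2 gives 28000 nM. In this assay compound 3 gives 11000 nM. Within the data shown here, both of these carry the 4-methoxycyclohexyl group on the amide-type nitrogen, and both return numbers rather than limits, though neither shares the rest of its structure with compound 1, so no measured step links them to it.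

Compound 4, `COc1cccc(OC)c1C(=O)Nc1c[nH]nc1C(=O)N[C@H]1CC[C@H](OC)CC1`, has not yet been measured. It differs from compound 1 in one place: 4-methoxycyclohexyl in place of pyridin-4-yl on an amide-type nitrogen. Since compound 1 is known only as a limit, the size of the step cannot be read from its own value. Compound 2 and compound 3 suggest that compounds bearing 4-methoxycyclohexyl on an amide-type nitrogen give measurable numbers rather than limits. The step in this assay is therefore expected to be small or none beyond the scatter, with an estimated at least 1.6-fold lower number from compound 1 to compound 4 (0.22 log units; that floor lies within the scatter). Compound 4 is expected to give about 30000 nM, within a range from 10000 nM to 100000 nM.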

Compound 4, half-maximal effective concentration: 31000 nM
For compound 4 the middle estimate is 1.0-fold (0.01 log units) below the measured one; the range from low to high includes it.
By their numbers in this assay, from the lowest: compound 3; then compounds 2 and 4 (each within the scatter of the next). At a limit, above all of these: compound 1.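

A single change on an amide-type nitrogen, 4-methoxycyclohexyl in place of pyridin-4-yl, can now be read directly in this assay, as an at least 1.6-fold lower number from compound 1 to compound 4 (0.20 log units; that floor lies within the scatter). Among these compounds, on this core, the change turns a read-out that stood only as a limit into a measured number, something compounds 2 and 3 could not show because no single-place step linked either of them to compound 1. The size of the step remains open, as the figure is only a floor, and compound 1 remains a limit of the assay and not a number: the limit of > 50000 nM in this assay, at which 1 of the 4 values shown sits.

The change replaces an aromatic ring containing nitrogen with a carbon-only non-aromatic ring and adds a methoxy group in one move, so the compounds shown do not separate these two parts. A plain cyclohexyl or a phenyl group on the same nitrogen would be needed to tell which part goes with the number, and the compounds shown also leave open how a piperidine or a longer chain would read out there.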